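Nitro for methyl on the aryl triazole: expected cell inhibition

The compounds below may be only part of what the source reports. "The series", "measured", "known", "first", "only" and "open" are said of these compounds alone.

Measured compounds:
compound 1 `CCOC(=O)C1=Cc2ccccc2OC1(OCc1cn(-c2ccc(C)cc2)nn1)C(F)(F)F`, 26700 nM
compound 2 `CCOC(=O)C1=Cc2ccccc2OC1(OCc1cc(-c2ccc(Cl)cc2)no1)C(F)(F)F`, 18200 nM
compound 3 `CCOC(=O)C1=Cc2ccccc2OC1(OCc1cn(CC(=O)Nc2ccc(OC)cc2)nn1)C(F)(F)F`, 28100 nM

All three were tested in a functional assay on MCF7 cells (Homo sapiens) for inhibition, read by MTT assay, with a stated time of 24 h; on this read-out higher numbers stand for weaker inhibition and lower numbers for stronger inhibition. Compound 1 stands in the middle of the three numbers; its values against compound 3 and compound 2 both lie within the usual scatter, so no ordering among them can be claimed.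

The unmeasured compound 4 `CCOC(=O)C1=Cc2ccccc2OC1(OCc1cn(-c2ccc([N+](=O)[O-])cc2)nn1)C(F)(F)F` differs from compound 1 by nitro in place of methyl on an aromatic carbon. For the measured compounds named here, the only measured step that bears on this region is a 1.1-fold higher number from compound 1 to compound 3 (0.02 log units; within the scatter), where a much larger exchange on the aromatic nitrogen left the number essentially unchanged. Going by the values given here, no step among the measured compounds shows any substituent change producing a shift beyond the scatter. The step of a 1.1-fold lower number from compound 1 to compound 4 (0.03 log units; within the scatter) is therefore expected to be small, with no clear direction. Compound 4 is estimated at 25000 nM, with a range from 10000 nM to 60000 nM.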

Compound 4, half-maximal inhibitory concentration: > 150000 nM
Compound 4 ended at the assay's limit; the forecaster's own chance of this, stated with the estimate: 20%; middle value at least 6.0-fold (0.77 log units) from the limit.
By their numbers in this assay, from the lowest: compounds 2, 1 and 3 (each within the scatter of the next). At a limit, above all of these: compound 4.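

In this assay, the change from 4-methylphenyl to 4-nitrophenyl is the first step among these compounds to pass beyond the scatter (an at least 5.6-fold higher number from compound 1 to compound 4 (0.74 log units; beyond the scatter)), so this position, para to a large group, is sensitive to what it carries. Putting 4-nitrophenyl in place of ((4-methoxyphenyl)carbamoyl)methyl gives a step of similar size (an at least 5.3-fold higher number from compound 3 to compound 4 (0.72 log units; beyond the scatter)). Compound 4 gives (> 150000 nM), which is a limit of the assay and not a number.

As far as these compounds go, how far compound 4 really lies from the others stays open. So does whether an amine or a carboxylic acid at this position would behave like the methyl or like the nitro.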